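Thiosemicarbazide series: removing a ring methyl from compound 3

The source may hold more compounds than are shown below. What is called first, only, known or untested is meant among the compounds shown, and "the series" means these compounds.

Three members of the series carry a measurement in a functional assay on HeLa cells (Homo sapiens) for cytotoxicity, read by MTT assay, with a stated time of 72 h, tested at 3 uM; on this read-out higher numbers stand for more inhibition of growth at the one concentration tested and lower numbers for less inhibition of growth. Compound 1 `N/C(=N\NC(=S)N1CCOCC1)c1ccccn1` gives 40% in this assay. Compound 2 `Cc1cccc(/C(N)=N/NC(=S)N2CCSCC2)n1` gives 54.6%. Compound 3 `Cc1ccnc(/C(N)=N/NC(=S)N2CCSCC2)c1` gives 40.4%, which puts it second highest of the three numbers: its nearest neighbour is compound 1, a number that lies within the scatter of the value of compound 3, and its furthest is compound 2, whose number lies beyond the scatter, higher than that of compound 3.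

Within the data shown here, no two measured compounds differ in a single place, so no step within the measured set can be read off directly. Compound 4 `N/C(=N\NC(=S)N1CCSCC1)c1ccccn1` has not yet been measured in this assay. Against compound 3 it shows (hydrogen in place of methyl on an aromatic carbon). Compound 1 shares the unsubstituted six-membered aromatic ring with compound 4 and differs from it only in the other ring of the shared core; its value and the value of compound 3 sit close together.

For compound 4 the step from compound 3 is expected to be small, as a number 3.6 percentage points higher from compound 3 to compound 4 (within the scatter), that is, none beyond the scatter in either direction. Compound 4 is therefore estimated at 44% in this assay, within a range from 30% to 60%.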

Compound 4, percent growth inhibition at one concentration: 39.7%
Compound 4: the middle estimate sits 4.3 percentage points above what was measured; measured number inside the range.
By their numbers in this assay, from the lowest: compounds 4, 1 and 3 (each within the scatter of the next); then compound 2.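

Replacing methyl with hydrogen on the aromatic carbon opposite the ring nitrogen and meta to a large group changes little in this assay (a number 0.7 percentage points lower from compound 3 to compound 4 (within the scatter)), so the methyl at this position can be removed without a change beyond the scatter. The same kind of exchange on compound 2, whose methyl stands on a different ring carbon, gives a modest step beyond the scatter (a number 14.9 percentage points lower from compound 2 to compound 4 (beyond the scatter)), so the outcome of removing a methyl depends on which ring carbon carries it in these compounds. The exchange of thiomorpholin-4-yl for morpholin-4-yl on the thiocarbonyl carbon also stays within the scatter (a number 0.3 percentage points lower from compound 1 to compound 4 (within the scatter)), so in the compounds with the unsubstituted aromatic ring the two groups give equivalent readings. Nothing available here accounts for the difference between the two methyl positions.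

Open, going by these compounds, is whether a group other than methyl at the position opposite the ring nitrogen, such as an ethyl, a methoxy or an amine, would move the reading beyond the scatter. Also open, on these data alone, is whether these readings at one concentration reflect the order that full concentration-response curves would give.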